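The source may report more compounds than this note shows. Statements on the series, on what has been measured and on what is new or still open speak of the compounds shown alone.

Compound 1 `Cc1ccc(/C=C2/N=C(c3ccccc3)N(C(=O)COc3ccccc3)NC2=O)cc1`: 300 mg/kg
Compound 2 `Cc1ccc(C(=O)N2NC(=O)/C(=C\c3ccc(O)cc3)N=C2c2ccccc2)cc1`: 30 mg/kg

Of the two compounds measured in a functional assay on the whole organism (strain albino) with Mus musculus as the target, with a stated time of 0.5 h (on this read-out higher numbers stand for an effect only at larger amounts of compound and lower numbers for an effect already at smaller amounts), compound 2 gives the lower number, 30 mg/kg, while compound 1 gives 300 mg/kg, a gap beyond the usual scatter. Compound 3 `Cc1ccc(/C=C2/N=C(c3ccccc3)N(C(=O)c3ccc(C)cc3)NC2=O)cc1` has not yet been measured. It differs from compound 2 in one place: methyl in place of hydroxy on an aromatic carbon. Among the measured compounds shown here, no measured pair shows this change on its own, so its effect is uncertain; compound 1 also carries a 4-methylphenyl on the shared core and gives the higher number, but it differs from compound 3 in a second place as well. The step from compound 2 to compound 3 in this assay is expected to be modest and upward, about a 3.3-fold higher number from compound 2 to compound 3 (0.52 log units; beyond the scatter). Compound 3 is expected to give 100 mg/kg, with a range from 30 mg/kg to 300 mg/kg.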

Compound 3, dose for half-maximal effect: 100 mg/kg
The estimate for compound 3 equals the measured number at the digits printed, within the range that was stated.
By their numbers in this assay, from the lowest: compound 2; then compound 3; then compound 1.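

In this assay, among the compounds shown here, the step of a 3.3-fold higher number from compound 2 to compound 3 (0.52 log units; beyond the scatter) gives the first direct reading of methyl in place of hydroxy on an aromatic carbon, para to a large group; this single change moves the number beyond the scatter. The step of a 3.0-fold lower number from compound 1 to compound 3 (0.48 log units; beyond the scatter) adds a second single-place comparison, showing that 4-methylphenyl in place of phenoxymethyl on a carbonyl carbon also moves the number beyond the scatter. No available measurement explains why either change has this result.

The compounds shown leave open how an amine or a methoxy group at the same ring position would compare with hydroxy and methyl.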